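Branched chain at the amide carbon: from compound 2 to compound 3

The source may report more compounds than this note shows. Statements on the series, on what has been measured and on what is new or still open speak of the compounds shown alone.

Measured so far:
compound 1 `CC(=O)c1ccc(NC(=O)CN(C(=O)c2ccccc2)S(=O)(=O)c2ccc(C)cc2)cc1` – 18.7%
compound 2 `CC(=O)c1ccc(NC(=O)C(CC(C)C)N(C(=O)c2ccccc2)S(=O)(=O)c2ccc(C)cc2)cc1` – 71.3%

In a functional assay for inhibition, read by spectrophotometry, with a stated time of 20 min, tested at 5 mg/mL (a higher number here means a stronger effect of the compound at the concentration tested, a lower number a weaker effect), compound 1 gives 18.7%, and compound 2 gives 71.3%. Going by the values given here, compound 2 stands highest of the two numbers; its nearest neighbour is compound 1, and the single measured step, a number 52.6 percentage points higher from compound 1 to compound 2 (beyond the scatter), is large and beyond the scatter.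

Compound 3 `CCC(C)C(C(=O)Nc1ccc(C(C)=O)cc1)N(C(=O)c1ccccc1)S(=O)(=O)c1ccc(C)cc1` differs from compound 2 by sec-butyl in place of isobutyl on a saturated chain carbon bound to an amide-type nitrogen and a carbonyl carbon. The two share every atom and differ only in how the chain is joined.

Among the compounds with values here, only one measured step bears on this change, the one from compound 1 to compound 2, and it concerns hydrogen against isobutyl, not isobutyl against sec-butyl. It shows that a branched chain at this carbon sits far above hydrogen, but gives no information on how two such chains compare with each other. Within the data shown here, with no step of that kind measured, the expectation for compound 3 is a number near that of compound 2, with a step of a number 6.3 percentage points lower from compound 2 to compound 3 (within the scatter) that is not expected to exceed the scatter.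

Compound 3 is therefore estimated at 65%, with a range from 42% to 85%.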

Compound 3, a percentage reported as inhibition, at one concentration (the size of the read-out at that concentration, not a potency): 47.3%
Compound 3: the middle estimate sits 17.7 percentage points above what was measured, within the range that was stated.
By their numbers in this assay, from the lowest: compound 1; then compound 3; then compound 2.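

In this assay the two chains are not interchangeable at this carbon: with the same atoms joined differently, sec-butyl in place of isobutyl gives a number 24 percentage points lower from compound 2 to compound 3 (beyond the scatter) and so the way the chain is joined matters here, not only the count of its atoms. Filling this position still raises the read-out with the second chain, since sec-butyl in place of hydrogen gives a number 28.6 percentage points higher from compound 1 to compound 3 (beyond the scatter) as a modest step, whereas the step from hydrogen to isobutyl is large. Nothing available accounts for the difference between the two chains.

The compounds shown leave open whether the rise over hydrogen holds for a shorter chain such as methyl, a longer chain such as n-hexyl or a ring-bearing group such as benzyl, and how a carboxylic acid or an amine on the chain would read in this assay as well. On these data alone, the read-out is the size of the effect at one concentration and not a potency, so it also remains open whether the order of compound 1, compound 3 and compound 2 would hold at other concentrations.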